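The source may hold more compounds than are shown below. What is called first, only, known or untested is meant among the compounds shown, and "the series" means these compounds.

Four compounds are compared in a functional assay on the whole organism (strain Swiss) with Mus musculus as the target, in the maximal electroshock model, with a stated time of 0.25 h, at a dose of 300 mg/kg by the intraperitoneal route; on this read-out higher numbers stand for a stronger effect at the one dose given and lower numbers for a weaker effect. Compound 1 `CC(C(=O)N1CCN(c2ccccc2F)CC1)N1C(=O)CCC1=O` is the strongest of the three measured compounds, giving 100% in this assay. Compound 2 `CCC(C(=O)N1CCN(c2ccc(C(F)(F)F)cc2)CC1)N1C(=O)CCC1=O` gives 25%, and compound 3 `CCC(C(=O)N1CCN(c2ccc(F)cc2)CC1)N1C(=O)CCC1=O` gives 0%. Compounds 2 and 3 share a core and differ in one place: trifluoromethyl in place of fluoro on an aromatic carbon. That change moved the activity a number 25 percentage points higher from compound 3 to compound 2 (beyond the scatter). Compound 4 `CC(C(=O)N1CCN(c2ccccc2C(F)(F)F)CC1)N1C(=O)CCC1=O` has not yet been measured; it comes from compound 1 by the same kind of change, (trifluoromethyl in place of fluoro on an aromatic carbon). The difference between the core of compound 1 and the core of compound 3 is not broken down here. The two changes are of the same kind but not the same: in the pair of compound 3 and compound 2 the new group sits para to a large group, whereas in compound 4 it sits ortho to a large group. Compound 1 already gives the full read-out, so no further rise can be recorded. The step from compound 1 to compound 4 is expected to be a number 15 percentage points lower from compound 1 to compound 4 (beyond the scatter), a small fall at most, resting on compound 1 with its 100% and on the earlier step of a number 25 percentage points higher from compound 3 to compound 2 (beyond the scatter). Compound 4 is therefore estimated at 85%, with a likely range from 50% to 100%.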

Compound 4, a percentage reported as activity, at one dose (the size of the read-out at that dose, not a potency): 100%
Compound 4: middle estimate off by 15 percentage points, on the low side; the range from low to high includes it.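

In this assay, trifluoromethyl in place of fluoro on an aromatic carbon gave no change at the digits printed from compound 1 to compound 4 (within the scatter). The same swap therefore does not bring a fixed gain wherever it is made in this series: the same change on two cores in this assay, a number 25 percentage points higher (beyond the scatter) from compound 3 to compound 2 and no change at the digits printed (within the scatter) from compound 1 to compound 4, 25 percentage points apart, beyond the scatter of two such steps This does not show that the swap is without effect on the core of compound 1: compound 1 gives 100%, the full read-out, so no rise could be recorded, and a read-out at one dose is not a potency. The two steps differ in their core and also in where the new group sits. In compound 4 the new group sits ortho to a large group, unlike in the earlier pair, and the data do not separate these two differences.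

The compounds shown leave open what a chlorine atom, a methoxy group or a nitrile on the same aromatic carbon would do. They also leave open whether compound 1 and compound 4 would still match at a lower dose, where the read-out has room to move in both directions.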